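Methyl addition on the tolyl ring of compound 1

The compounds below may be only part of what the source reports. "The series", "measured", "known", "first", "only" and "open" are said of these compounds alone.

Measured compounds
- compound 1 `Cc1ccc(C2=NN(C3=NC(c4ccccc4)CS3)C(c3ccc4ccccc4c3)C2)cc1`: 14700 nM
- compound 2 `O=C1CSC(N2N=C(c3ccc(Br)cc3)CC2c2ccc3ccccc3c2)=N1`: 18200 nM

In a functional assay on HepG2 cells (Homo sapiens) for inhibition, read by CCK-8 assay, with a stated time of 48 h (on this read-out lower numbers stand for stronger inhibition and higher numbers for weaker inhibition), compound 1 gives 14700 nM and compound 2 gives 18200 nM; the two numbers lie within the scatter of each other, so no order between them can be read, and compound 1 simply serves as the reference point for the next step. The two compounds differ in more than one place, so nothing is computed between them.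

Compound 3 `Cc1ccc(C2=NN(C3=NC(c4ccccc4)CS3)C(c3ccc4ccccc4c3)C2)cc1C` carries the change (methyl in place of hydrogen on an aromatic carbon), methyl in place of hydrogen on an aromatic carbon. Among the measured compounds shown here, no measured pair shows this change, so the expected step in this assay is taken as none beyond the scatter, in no preferred direction.

For compound 3 the estimate in this assay is therefore 13000 nM, with a range from 5000 nM to 32000 nM, the expected step being a 1.1-fold lower number from compound 1 to compound 3 (0.05 log units; within the scatter).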

Compound 3, half-maximal inhibitory concentration: 7370 nM
Compound 3: middle estimate off by 1.8-fold (0.25 log units), on the high side; the range from low to high includes it.
By their numbers in this assay, from the lowest: compounds 3, 1 and 2 (each within the scatter of the next, the first and the last beyond it).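

Among the compounds shown here, this is the first pair that differs in one place: in this assay, going from 4-methylphenyl to 3,4-dimethylphenyl gives a 2.0-fold lower number from compound 1 to compound 3 (0.30 log units; within the scatter) and so the added methyl, on an aromatic carbon ortho to a methyl group, cannot be said to move the read-out in either direction. This place on the ring therefore takes one further methyl without a step beyond the scatter, though a single pair shows nothing more general. Nothing on hand bears on the reason for the size of this step.

From the compounds shown here alone, whether a different group at this place, such as an ethyl chain, a methoxy group, an amine or a carboxylic acid, gives a step beyond the scatter remains open. Also open, going by these compounds, is whether the same methyl change reads alike on the core of compound 2.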